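Swapping a small methyl for a large aryl group

A few compounds are considered here, and "the series" means these few. Any claim that something is new, unique, unknown or untested is made for them only; others in the source may bear on it.

Compound 1 `CCOCCOC(=O)C(=O)Nc1nc(-c2cc(-c3c(F)cccc3Cl)no2)cs1` gives 1.1 mg/kg
Compound 2 `Cc1cc(-c2csc(NC(=O)C(=O)O)n2)on1` gives 0.3 mg/kg

In a functional assay on the whole organism with Rattus norvegicus as the target (a lower number here means that less compound is needed, a higher number that more compound is needed for the effect), compound 2 has the lower number of the two (0.3 mg/kg), and its gap to compound 1 lies beyond the usual scatter. Compound 3 `O=C(O)C(=O)Nc1nc(-c2cc(-c3c(F)cccc3Cl)no2)cs1` differs from compound 2 by 2-chloro-6-fluorophenyl in place of methyl on an aromatic carbon and has not yet been measured. Among the measured compounds shown here, no measured pair shows this change alone. For the measured compounds named here, the only measured compound carrying the new group is compound 1 (1.1 mg/kg), which points to a moderate rise. In this assay an upward step a 2.7-fold higher number from compound 2 to compound 3 (0.43 log units; beyond the scatter) is therefore expected, though the estimate is uncertain. For compound 3 the estimated value is 0.8 mg/kg (expected range 0.15 mg/kg to 4 mg/kg).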

Compound 3, dose for half-maximal effect: 2.4 mg/kg
Beside the measured number, compound 3's estimate is 3.0-fold (0.48 log units) below it, and the stated range covers the measured number.
By their numbers in this assay, from the lowest: compound 2; then compound 1; then compound 3.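

In this assay, the exchange at this position can now be read directly: 2-chloro-6-fluorophenyl in place of methyl gives an 8.0-fold higher number from compound 2 to compound 3 (0.90 log units; beyond the scatter), so more compound is needed with the aryl group on the shared core. With that aryl group kept, hydrogen in place of 2-ethoxyethyl on an oxygen next to a carbonyl group gives a 2.2-fold higher number from compound 1 to compound 3 (0.34 log units; beyond the scatter), so the free acid needs more compound than its ester. From the compounds shown here alone, how ethyl or an unsubstituted phenyl would compare at this position remains open. Nothing measured here explains either step.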